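Free Acid Glycoside Expected to Stay Beyond the Limit

The compounds below may be only part of what the source reports. "The series", "measured", "known", "first", "only" and "open" are said of these compounds alone.

Compound 1 `C/C=C1/[C@H](O[C@@H]2O[C@H](CO)[C@@H](O)[C@H](O)[C@H]2O)OC=C(C(=O)O)[C@H]1CC(=O)OC`: > 20000 nM
Compound 2 `C/C=C1/[C@H](O[C@@H]2O[C@H](CO)[C@@H](O)[C@H](O)[C@H]2O)OC=C(C(=O)OC)[C@H]1CC(=O)O`: > 15000 nM
Compound 3 `C/C=C1/[C@H](O[C@@H]2O[C@H](CO)[C@@H](O)[C@H](O)[C@H]2O)OC=C(C(=O)OC)[C@H]1CC(=O)OCCc1ccc(OC)cc1`: > 20000 nM

In a functional assay on SK-BR-3 cells (Homo sapiens) for antiproliferative activity, read by MTT assay, with a stated time of 72 h (on this read-out lower numbers stand for stronger inhibition and higher numbers for weaker inhibition), compound 1 gives > 20000 nM, which is a limit of the assay rather than a number. Compound 2 gives > 15000 nM, likewise a limit. Compound 3 gives > 20000 nM, again a limit. Compound 2 thus stands only at a limit, as do the two others the limit of > 15000 nM in this assay, at which 1 of the 3 values shown sits (the limit of > 20000 nM in this assay, at which 2 of the 3 values shown sit), and the step that the two limits leave unreadable from compound 2 to compound 3 cannot be read. Compound 4 `C/C=C1/[C@H](O[C@@H]2O[C@H](CO)[C@@H](O)[C@H](O)[C@H]2O)OC=C(C(=O)O)[C@H]1CC(=O)O` differs from compound 2 by hydrogen in place of methyl on an oxygen next to a carbonyl group. Within the data shown here, no measured step bears on this change with a readable size, and no compound of the set has reached a number. The step that the limit leaves unreadable from compound 2 to compound 4 is therefore expected to remain unreadable, with compound 4 expected to stay at a limit. For compound 4 the estimate is 30000 nM, within a range from 10000 nM to 100000 nM.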

Compound 4, half-maximal inhibitory concentration: > 50000 nM
Compound 4: a limit, no number (the forecaster's own chance of this, stated with the estimate: 85%); middle value at least 1.6-fold (0.22 log units) away from the limit.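

Compound 4 gives > 50000 nM in this assay, which is a limit, so its steps from compound 1 and from compound 2 cannot be read. The compounds shown leave open what change to the shared core, if any, would reach a number in this assay.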